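Factor X sulfonamide series: from compound 3 to compound 4

This account rests on a few compounds, and the source may have more. Where it says the series, first, only, none or still open, it means among the compounds named here.

Measured so far in an assay on isolated protein for inhibition of coagulation factor X (Oryctolagus cuniculus), tested at 1 uM; on this read-out higher numbers stand for more inhibition at the one concentration tested (going by the name of the read-out) and lower numbers for less inhibition:
compound 1 `O=C1[C@@H](NS(=O)(=O)c2ccc(-c3ccon3)s2)CCN1Cc1cc2cc[nH]cc-2n1` gives 49%
compound 2 `O=C1[C@@H](NS(=O)(=O)c2cc3c(Cl)nccc3s2)CCN1CCNc1ccncc1` gives 39%
compound 3 `Cc1c(S(=O)(=O)N[C@H]2CCN(Cc3cc4[nH]cccc-4n3)C2=O)sc2ccc(Cl)cc12` gives 40%

Compound 3 stands second highest of these three numbers, yet its nearest neighbour, compound 2, lies within the scatter of it, and so does compound 1, the one furthest away; the three values cannot be ordered with confidence. Compound 4 `Cc1c(S(=O)(=O)N[C@H]2CCN(Cc3cc4c[nH]ccc-4n3)C2=O)sc2ccc(Cl)cc12` has the same atoms as compound 3, joined differently: a group of 9 heavy atoms (7 carbon, 2 nitrogen; one five-membered aromatic ring with 1 hetero atom, one six-membered aromatic ring with 1 hetero atom) in place of a group of 9 heavy atoms (7 carbon, 2 nitrogen; one five-membered aromatic ring with 1 hetero atom, one six-membered aromatic ring with 1 hetero atom), on a saturated chain carbon bound to an amide-type nitrogen in a ring. For the measured compounds named here, no measured pair in the set differs at this position, so nothing calibrates this rearrangement. The step in this assay is expected to be no change at the digits printed from compound 3 to compound 4 (within the scatter), not beyond the scatter in either direction. Compound 4 is accordingly estimated at 40%, with a range from 25% to 55%.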

Compound 4, a percentage reported as inhibition, at one concentration (the size of the read-out at that concentration, not a potency): 37%
Beside the measured number, compound 4's estimate is 3 percentage points above it, within the range that was stated.
By their numbers in this assay, from the lowest: compounds 4, 2, 3 and 1 (each within the scatter of the next, the first and the last beyond it).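

In this assay, for the compounds shown here, the only step read at this position is a number 3 percentage points lower from compound 3 to compound 4 (within the scatter), for two groups with the same atoms joined differently, on a saturated chain carbon bound to an amide-type nitrogen in a ring. At the one concentration tested, this rearrangement therefore gives no readable difference with this sulfonamide part held constant. No available evidence bears on this result.

On these data alone, whether a primary amine or a carboxylic acid at this place would give a number beyond the scatter remains open. Potency also remains unread, as only one concentration is reported.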